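Compound 3 to compound 4: a different piperazine on the carbonyl

The source may report more compounds than this note shows. Statements on the series, on what has been measured and on what is new or still open speak of the compounds shown alone.

In an ADME assay on microsomes from liver (Homo sapiens) for metabolic stability, read by LC-MS, using NADPH, with a stated time of 60 min, tested at 0.1 uM (a higher number here means that more of the compound is left, a lower number that less of the compound is left), compound 1 `Fc1ccc(Nc2cc3[nH]c(Nc4cc(N5CCNCC5)ccn4)nc3cn2)cc1C(F)(F)F` gives 98% and compound 2 `FC1(F)CC(Nc2cc3[nH]c(Nc4ccc(N5CCN(CC6CC6)CC5)cn4)nc3cn2)C1` gives 86% while compound 3 `O=C(c1ccnc(Nc2nc3cnc(Nc4ccc(F)c(C(F)(F)F)c4)cc3[nH]2)c1)N1CCN(C2CC2)CC1` gives 77% here, within the scatter of compound 2 and beyond the scatter under compound 1. Next comes compound 4 `C[C@@H]1CN(C(=O)c2ccnc(Nc3nc4cnc(Nc5ccc(F)c(C(F)(F)F)c5)cc4[nH]3)c2)C[C@H](C)N1` with 3,5-dimethylpiperazin-1-yl in place of 4-cyclopropylpiperazin-1-yl on a carbonyl carbon as the change, 3,5-dimethylpiperazin-1-yl in place of 4-cyclopropylpiperazin-1-yl on a carbonyl carbon. Among the compounds with values here, one measured step bears on this place, a number 21 percentage points lower from compound 1 to compound 3 (beyond the scatter) but it exchanges piperazin-1-yl for the whole (4-cyclopropylpiperazin-1-yl)carbonyl. Within the data shown here, no measured pair isolates the present change, so no shift beyond the scatter is expected, and the expected step is a number 3 percentage points higher from compound 3 to compound 4 (within the scatter) in this assay for now. Compound 4 is estimated at 80% with 62% to 95% as the expected range.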

Compound 4, percent of the compound remaining: 89%
Compound 4: the middle estimate sits 9 percentage points below what was measured; measured number inside the range.
By their numbers in this assay, from the lowest: compounds 3, 2, 4 and 1 (each within the scatter of the next, the first and the last beyond it).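

Within the data shown here, on the carbonyl carbon, 3,5-dimethylpiperazin-1-yl in place of 4-cyclopropylpiperazin-1-yl gives a number 12 percentage points higher from compound 3 to compound 4 (beyond the scatter) in this assay, the first step that isolates the group on the carbonyl. Against piperazin-1-yl on an aromatic carbon, (3,5-dimethylpiperazin-1-yl)carbonyl gives a number 9 percentage points lower from compound 1 to compound 4 (within the scatter), so the drop seen with (4-cyclopropylpiperazin-1-yl)carbonyl does not carry over to this amide. No measurement available here accounts for the step.

Still open, from the compounds shown here alone, is whether the step follows the loss of the cyclopropyl or the arrival of the two methyl groups with their defined stereocentres. Plain piperazin-1-yl or 4-methylpiperazin-1-yl on the same carbonyl would separate the two.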